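Extending a single observed step to an untested analogue

The source may hold more compounds than are shown below. What is called first, only, known or untested is meant among the compounds shown, and "the series" means these compounds.

Measured compounds:
Compound 1 `C=CC(=O)Nc1cccc(Oc2nc(Nc3cccc(C#N)c3)nc3c2CSCC3)c1`: 34900 nM
Compound 2 `C/C=C/C(=O)Nc1cccc(Oc2nc(Nc3cccc(C#N)c3)nc3c2CSCC3)c1`: 12800 nM
Compound 3 `C=CC(=O)Nc1cccc(Oc2nc(Nc3ccc(OC)cc3)nc3c2CSCC3)c1`: 20900 nM

These values come from a functional assay on HeLa cells (Homo sapiens) for antiproliferative activity, read by MTT assay, with a stated time of 72 h; on this read-out higher numbers stand for weaker inhibition and lower numbers for stronger inhibition. Compound 4 `C/C=C/C(=O)Nc1cccc(Oc2nc(Nc3ccc(OC)cc3)nc3c2CSCC3)c1` has not yet been measured there.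

Compound 2 is compound 1 with one change, (prop-1-en-1-yl in place of vinyl on a carbonyl carbon), and this gave a 2.7-fold lower number from compound 1 to compound 2 (0.44 log units; beyond the scatter). Compound 3 is compound 1 with a different change, (4-methoxyphenyl in place of 3-cyanophenyl on a nitrogen on an aromatic ring), and this gave a 1.7-fold lower number from compound 1 to compound 3 (0.22 log units; within the scatter), so compound 1 and compound 3 cannot be told apart with confidence.

Compound 4 carries the same change relative to compound 3 that compound 2 carries relative to compound 1: prop-1-en-1-yl in place of vinyl on a carbonyl carbon. The surroundings of the change are the same in both pairs, so it is the same change, made on a core that differs in the way described by 4-methoxyphenyl in place of 3-cyanophenyl on a nitrogen on an aromatic ring. Among the compounds with values here, only one example of this change is available, so the expectation rests on that single step.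

For compound 4 in this assay a step of about a 2.5-fold lower number from compound 3 to compound 4 (0.39 log units; beyond the scatter) is expected, because compound 1 to compound 2 showed a 2.7-fold lower number from compound 1 to compound 2 (0.44 log units; beyond the scatter). Compound 4 is therefore estimated at 8500 nM, with a likely range from 3500 nM to 20000 nM.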

Compound 4, half-maximal inhibitory concentration: > 50000 nM
Compound 4 ended at the assay's limit (the forecaster's own chance of this, stated with the estimate: 0%); at least 5.8-fold (0.76 log units) between middle value and limit.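

In this assay compound 4 gives > 50000 nM, which is a limit of the assay and not a number. Prop-1-en-1-yl in place of vinyl on a carbonyl carbon does not carry over from one core to the other, giving an at least 2.3-fold higher number from compound 3 to compound 4 (0.37 log units; beyond the scatter), which runs opposite to the earlier step on the core of compound 1: the same change on two cores in this assay, a 2.7-fold lower number (0.44 log units; beyond the scatter) from compound 1 to compound 2 and an at least 2.3-fold higher number (0.37 log units; beyond the scatter) from compound 3 to compound 4, at least 6.5-fold (0.81 log units) apart, beyond the scatter of two such steps Seen the other way round, 4-methoxyphenyl in place of 3-cyanophenyl gives an at least 3.9-fold higher number from compound 2 to compound 4 (0.59 log units; beyond the scatter), so the two changes do not act independently in these four compounds, yet this set cannot show the cause, or how far compound 4 really lies past the limit: the same change on two cores in this assay, a 1.7-fold lower number (0.22 log units; within the scatter) from compound 1 to compound 3 and an at least 3.9-fold higher number (0.59 log units; beyond the scatter) from compound 2 to compound 4, at least 6.5-fold (0.81 log units) apart, beyond the scatter of two such steps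

From the compounds shown here alone, it remains open whether this reversal belongs to 4-methoxyphenyl alone or would also appear with another group on that nitrogen, such as a plain phenyl. Going by these compounds, it is equally open how a longer chain or an amine in place of prop-1-en-1-yl on a carbonyl carbon would behave on either core.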